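Acyl swaps on the shared core: compound 3 to compound 4

The source may report more compounds than this note shows. Statements on the series, on what has been measured and on what is new or still open speak of the compounds shown alone.

Measured compounds, with values from a functional assay on NCI-H1650 cells (Homo sapiens) for inhibition, read by sulforhodamine B assay, with a stated time of 3 days (on this read-out lower numbers stand for stronger inhibition and higher numbers for weaker inhibition), as follows

compound 1 `CN1CCN(c2cccc(N/C=C3\C(=O)Nc4ccc(NC(=O)c5cccc(F)c5)cc43)c2)CC1` gives 4280 nM
compound 2 `CN1CCN(c2cccc(N/C=C3\C(=O)Nc4ccc(NC(=O)c5c(F)cccc5F)cc43)c2)CC1` gives 1630 nM
compound 3 `CN1CCN(c2cccc(N/C=C3\C(=O)Nc4ccc(NC(=O)c5ccc[nH]5)cc43)c2)CC1` gives 7560 nM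

Compound 3 sits level with compound 1 within the scatter (a 1.8-fold higher number from compound 1 to compound 3 (0.25 log units; within the scatter)) and clearly above compound 2 (a 4.6-fold higher number from compound 2 to compound 3 (0.67 log units; beyond the scatter)). Compound 4 `CC(C)CC(=O)Nc1ccc2c(c1)/C(=C/Nc1cccc(N3CCN(C)CC3)c1)C(=O)N2` carries isobutyl in place of 1H-pyrrol-2-yl on a carbonyl carbon. Swaps at this carbonyl carbon have so far been modest at most, the largest being (a 4.6-fold higher number from compound 2 to compound 3 (0.67 log units; beyond the scatter)) and another (a 2.6-fold lower number from compound 1 to compound 2 (0.42 log units; beyond the scatter)). Among the compounds with values here, no measured compound has a group without a ring here, so the direction is poorly supported. In this assay the expected change is small and within the scatter (a 1.3-fold lower number from compound 3 to compound 4 (0.10 log units; within the scatter)). For compound 4 the estimated value is 6000 nM (expected range 2500 nM to 14000 nM).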

Compound 4, half-maximal inhibitory concentration: 5870 nM
The estimate for compound 4 lay 1.0-fold (0.01 log units) above the measured number, and the stated range covers the measured number.
By their numbers in this assay, from the lowest: compound 2; then compounds 1, 4 and 3 (each within the scatter of the next).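

In this assay, within the data shown here, isobutyl, the only group here without a ring on this carbonyl carbon, stays level with 1H-pyrrol-2-yl (a 1.3-fold lower number from compound 3 to compound 4 (0.11 log units; within the scatter)) and with 3-fluorophenyl (a 1.4-fold higher number from compound 1 to compound 4 (0.14 log units; within the scatter)), so matching compounds 1 and 3 does not require a ring at this place. Only 2,6-difluorophenyl stands apart, with the lower number (a 3.6-fold higher number from compound 2 to compound 4 (0.56 log units; beyond the scatter)). No measurement shown offers an explanation for either result.

Still open, on these data alone, is whether a longer chain, an amine or a carboxylic acid on this carbonyl carbon would keep these numbers or shift them.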